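The compounds below may be only part of what the source reports. "The series", "measured", "known", "first", "only" and "open" are said of these compounds alone.

Compound 1 `COc1cccc(N2C(=O)COc3ccc(-c4cnc(Cl)c(NS(=O)(=O)c5ccc(F)cc5)c4)cc32)c1`: > 40000 nM (a limit)
Compound 2 `O=C1COc2ccc(-c3cnc(Cl)c(NS(=O)(=O)c4ccc(F)cc4)c3)cc2N1c1ccc(F)cc1`: 34200 nM
Compound 3 `O=C1COc2ccc(-c3cnc(Cl)c(NS(=O)(=O)c4ccc(F)cc4)c3)cc2N1`: > 40000 nM (a limit)

All three compounds were tested in a functional assay on HCT-116 cells (Homo sapiens) for antiproliferative activity, read by MTT assay, with a stated time of 72 h; a higher number here means a weaker inhibitor, a lower number a stronger inhibitor. Compound 3 has no number there, only (the limit of > 40000 nM in this assay, at which 2 of the 3 values shown sit). Compound 4 `O=C1COc2ccc(-c3cnc(Cl)c(NS(=O)(=O)c4ccc(F)cc4)c3)cc2N1C1CC1` differs from compound 3 by cyclopropyl in place of hydrogen on an amide-type nitrogen in a ring.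

The measured steps that bear on this change all alter the group at that same nitrogen. They are an at least 1.1-fold higher number from compound 2 to compound 3 (0.06 log units; that floor lies within the scatter), an at least 1.1-fold lower number from compound 1 to compound 2 (0.06 log units; that floor lies within the scatter) and a step that the two limits leave unreadable from compound 1 to compound 3. None of them is shown to go beyond the scatter, and the last cannot be read at all. Within the data shown here, compound 2, with a 4-fluorophenyl on that nitrogen, gives 34200 nM, the only true number. Neither of the two aryl groups tested there is shown to move the result away from the top of the range of this assay.

No step beyond the scatter is therefore expected in either direction, and a further limit is about as likely as a number. The expected step is an at least 1.1-fold lower number from compound 3 to compound 4 (0.04 log units; that floor lies within the scatter). For compound 4 the estimated value is 36000 nM, with an expected range from 20000 nM to 65000 nM.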

Compound 4, half-maximal inhibitory concentration: 12400 nM
Compound 4: middle estimate off by 2.9-fold (0.46 log units), on the high side, outside the stated range (below it).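

In this assay, the group on the amide-type nitrogen in a ring is now shown to move the result beyond the scatter: cyclopropyl in place of hydrogen gives an at least 3.2-fold lower number from compound 3 to compound 4 (0.50 log units; beyond the scatter). Cyclopropyl also does better than both aryl groups, with a 2.8-fold lower number from compound 2 to compound 4 (0.44 log units; beyond the scatter) for the change from 4-fluorophenyl and an at least 3.2-fold lower number from compound 1 to compound 4 (0.50 log units; beyond the scatter) for the change from 3-methoxyphenyl, so among the four compounds this position responds to the kind of group it carries, and a non-aromatic ring of carbon only gives the lowest number. The two steps that start from a limit give only a floor for their size: the limit of > 40000 nM in this assay, at which 2 of the 4 values shown sit.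

The compounds shown leave open whether this gain belongs to the three-membered ring as such, or would also come with an open chain such as isopropyl or a larger ring such as cyclohexyl. They also leave open how an amine or a carboxylic acid carried on a chain at this nitrogen would read in this assay, and whether the effect of cyclopropyl would hold with changes elsewhere on the shared core.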